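Shortening the butoxy chain of compound 2

The source may report more compounds than this note shows. Statements on the series, on what has been measured and on what is new or still open speak of the compounds shown alone.

Within the data shown here, in a functional assay on KBVIN cells (Homo sapiens) for antiproliferative activity, read by sulforhodamine B assay, with a stated time of 3 days (a lower number here means that less compound is needed, a higher number that more compound is needed for the effect), compound 1 `CCCC1=C(OC)C(CCC)(CCC)C(=O)/C(=C(O)\C=C\c2ccccc2)C1=O` gives 3.4 uM and compound 2 `CCCCOC1=C(CCC)C(=O)/C(=C(O)/C=C/c2ccccc2)C(=O)C1(CCC)CCC` gives 8.9 uM, the higher of the two numbers so far. Compound 3 `CCCC1=C(OCC)C(CCC)(CCC)C(=O)/C(=C(O)\C=C\c2ccccc2)C1=O` keeps the shared core and turns butoxy to ethoxy: hydrogen in place of ethyl on a saturated chain carbon, two bonds along the chain from an oxygen on an unsaturated carbon. Among the measured compounds shown here, one measured step bears on this change, on the same chain: a 2.6-fold higher number from compound 1 to compound 2 (0.42 log units; beyond the scatter), modest and beyond the scatter. Compound 3 has a chain length between those of the two measured compounds, so its number in this assay is expected to fall between theirs. The expected change is small and lower, a 1.7-fold lower number from compound 2 to compound 3 (0.23 log units; within the scatter), and may not clear the scatter. For compound 3 the estimated value is 5.2 uM, with an expected range of 2.8 uM to 9.5 uM.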

Compound 3, concentration for half-maximal effect: 3.5 uM
Compound 3: the middle estimate sits 1.5-fold (0.17 log units) above what was measured; measured number inside the range.
By their numbers in this assay, from the lowest: compounds 1 and 3 (each within the scatter of the next); then compound 2.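

Shortening butoxy to ethoxy gives a clear change in this assay (a 2.5-fold lower number from compound 2 to compound 3 (0.41 log units; beyond the scatter)), so the two outer carbons of the butoxy chain alone account for a step beyond the scatter. Going on to methoxy adds nothing measurable (a 1.0-fold higher number from compound 1 to compound 3 (0.01 log units; within the scatter)), and this step lies within the scatter. Among these three compounds, the number therefore does not follow chain length evenly: methoxy and ethoxy cannot be told apart, and only butoxy stands apart from them, a shape the single step from compound 1 to compound 2 could not show. No supporting data explain this result.

The compounds shown leave open whether propoxy already behaves like butoxy and whether a chain longer than butoxy raises the number further. They also leave open how a terminal amine or carboxylic acid on the ethoxy chain would read.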